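The source may hold more compounds than are shown below. What is called first, only, known or untested is meant among the compounds shown, and "the series" means these compounds.

Working notes on a chalcone series carrying a dithiocarbamate on an alkoxy chain. Compound 1, `O=C(/C=C/c1cccs1)c1ccc(OCCSC(=S)N2CCCC2)cc1`, is the reference point here. In a functional assay on MGC-803 cells (Homo sapiens) for inhibition, read by MTT assay, with a stated time of 72 h (on this read-out higher numbers stand for weaker inhibition and lower numbers for stronger inhibition), compound 1 gives 32400 nM. Two further members have been run. Compound 2, `COc1cc(/C=C/C(=O)c2ccc(OCCCSC(=S)N3CCCC3)cc2)cc(OC)c1OC`, gives 14500 nM in this assay. Compound 3, `CN1CCN(C(=S)SCCCOc2ccc(C(=O)/C=C/c3cc(Cl)cc(Cl)c3)cc2)CC1`, gives 19400 nM in this assay. Compound 1 thus has the highest number of the three; its gap to compound 3 lies within the scatter, so the two cannot be ordered, while its gap to compound 2 lies beyond the scatter, with compound 2 showing the lower number.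

Compound 4, `O=C(/C=C/c1ccc(Cl)cc1)c1ccc(OCCSC(=S)N2CCCC2)cc1`, has not yet been run in this assay. It differs from compound 1 in a single place: 4-chlorophenyl in place of thiophen-2-yl on a double-bonded chain carbon bound to a double-bonded chain carbon. Among the measured compounds shown here, no step between measured compounds exists that tracks this kind of change, so the expectation can rest only on the numbers above and on the change itself. The step from compound 1 to compound 4 is expected to be small, a 1.5-fold lower number from compound 1 to compound 4 (0.17 log units; within the scatter), towards a somewhat lower number, and it may well not exceed the scatter. Compound 4 is accordingly estimated at 22000 nM in this assay, within a range of 9000 nM to 55000 nM.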

Compound 4, half-maximal inhibitory concentration: 47900 nM
Compound 4: the middle estimate sits 2.2-fold (0.34 log units) below what was measured; measured number inside the range.
By their numbers in this assay, from the lowest: compounds 2, 3, 1 and 4 (each within the scatter of the next, the first and the last beyond it).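

Among the compounds shown here, this is the first one-place step, and it shows that at this position, on a double-bonded chain carbon bound to a double-bonded chain carbon, 4-chlorophenyl in place of thiophen-2-yl gives a 1.5-fold higher number from compound 1 to compound 4 (0.17 log units; within the scatter) in this assay. Thiophen-2-yl and 4-chlorophenyl therefore cannot be ordered here, even though the change replaces a five-membered aromatic ring with 1 hetero atom by a six-membered aromatic ring of carbon only that carries a chlorine. Nothing on hand explains this result or links it to a property of either group.

Going by these compounds, whether this tolerance extends to other groups at this place, such as furan-2-yl, 4-methoxyphenyl or a phenyl ring bearing a carboxylic acid, remains open, since a single step cannot define the range of the position. On these data alone, the contribution of the alkoxy chain also remains open, including that of a longer chain, and so does that of the amine on the dithiocarbamate, as compounds 2 and 3 differ from compound 1 in more than one place and give no isolated reading of either.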